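Replacing cyclohexylamino with 2-ethylbutoxy: notes on the series

The source may hold more compounds than are shown below. What is called first, only, known or untested is meant among the compounds shown, and "the series" means these compounds.

Measured so far in a physicochemical assay for lipophilicity, using the shake flask method, measured as octanol-water partition, at pH 7.4 (on this read-out lower numbers stand for lower lipophilicity and higher numbers for higher lipophilicity), are these compounds:
compound 1 (`CCC(CC)CNc1c(C(N)=O)cnc2ccc(C#N)cc12`) with 3.5
compound 2 (`NC(=O)c1cnc2ccc(-c3cccnc3)cc2c1NC1CCCCC1`) with 3.8

These two values lie within the scatter of each other, so compound 2 stands level with compound 1 on the numbers available. Going by the values given here, the two compounds differ in more than one place, and no measured step isolates a single change.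

The next compound is compound 3 (`CCC(CC)COc1c(C(N)=O)cnc2ccc(-c3cccnc3)cc12`), which has 2-ethylbutoxy in place of cyclohexylamino on an aromatic carbon, opposite the ring nitrogen (2-ethylbutoxy in place of cyclohexylamino on an aromatic carbon). Among the compounds with values here, no measured pair covers this exchange, so the expectation is only tentative. The expected step is a number 0.20 log units higher from compound 2 to compound 3 (within the scatter) in this assay and is a small rise, not clearly beyond the scatter. For compound 3 the estimated value is 4 with an expected range from 3.5 to 4.5 for the measurement.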

Compound 3, distribution coefficient: > 4.3
Compound 3 was reported as a limit; the forecaster's own chance of this, stated with the estimate: 3%; middle value at least 0.30 log units from the limit.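

Going by these compounds alone, this is the first step that isolates a single change: at the position opposite the ring nitrogen, 2-ethylbutoxy in place of cyclohexylamino gives a number at least 0.50 log units higher from compound 2 to compound 3 (beyond the scatter). In this assay compound 3 gives > 4.3, which is a limit of the assay and not a number. The step therefore has a lower bound only, and its full size cannot be read, because the reading rests on that limit: the limit of > 4.3 in this assay, at which 1 of the 3 values shown sits.

The exchange replaces the nitrogen link with oxygen and the ring with an open chain at once, and no pair shown separates these two changes. Cyclohexyloxy at this position could separate them, while a shorter alkoxy chain would show whether the step depends on the length of the chain.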